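Three Stable Ethers and an Untested Propyl Analogue

The compounds below may be only part of what the source reports. "The series", "measured", "known", "first", "only" and "open" are said of these compounds alone.

The measured compounds:
compound 1, `COc1cccc(CCOc2ccc(-c3c(C)nc(C)c([C@H](OC(C)(C)C)C(=O)O)c3N3CCC(C)(C)CC3)cc2)c1`, gives in an ADME assay on microsomes from liver (Rattus norvegicus) for metabolic stability, read by LC-MS, tested at 0.5 uM (a lower number here means that the compound disappears faster, a higher number that the compound lasts longer), a value of > 2 h, which is a limit of the assay.
compound 2, `Cc1cc(CCOc2ccc(-c3c(C)nc(C)c([C@H](OC(C)(C)C)C(=O)O)c3N3CCC(C)(C)CC3)cc2)ccc1F`, gives in this assay a value of > 2 h, again a limit.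
compound 3, `Cc1nc(C)c([C@H](OC(C)(C)C)C(=O)O)c(N2CCC(C)(C)CC2)c1-c1ccc(OCCc2ccc(F)cc2F)cc1`, gives in this assay a value of > 2 h, also a limit.

Compound 3 therefore stands where every measured value sits: the limit of > 2 h in this assay, at which 3 of the 3 values shown sit. None of the steps among the three can be sized, since a step that the two limits leave unreadable from compound 1 to compound 2, a step that the two limits leave unreadable from compound 1 to compound 3 and a step that the two limits leave unreadable from compound 2 to compound 3 all run between limits.

Compound 4, `Cc1nc(C)c([C@H](OC(C)(C)C)C(=O)O)c(N2CCC(C)(C)CC2)c1-c1ccc(CCCc2ccc(F)cc2)cc1`, differs from compound 3 by 3-(4-fluorophenyl)propyl in place of 2-(2,4-difluorophenyl)ethoxy on an aromatic carbon. The measured steps bear on this change only loosely: they swap substituents on the aryl ring at the end of the chain, whereas here the chain itself is altered, and none of them is readable. No step beyond the scatter can therefore be expected in this assay on this evidence, in either direction. Compound 4 is estimated to give 2.5 h, within 1 h to 6 h, which as a step from compound 3 is expected to amount to a step that the limit leaves unreadable from compound 3 to compound 4.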

Compound 4, half-life: > 2 h
Compound 4 gave a limit, no number; the forecaster's own chance of this, stated with the estimate: 60%; the middle value is on the limit's open side.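

In this assay compound 4 gives > 2 h, which is a limit. Within the data shown here, no step from compound 1, compound 2 or compound 3 to compound 4 can be read: the limit of > 2 h in this assay, at which 4 of the 4 values shown sit. The compounds shown leave open what the half-life of any of them is, and whether 3-(4-fluorophenyl)propyl differs at all from the ethoxy groups it replaces.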